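Chloro for Hydrogen on the Shared Core

The source may hold more compounds than are shown below. What is called first, only, known or untested is meant among the compounds shown, and "the series" means these compounds.

Measured compounds:
compound 1 `O=S(=O)(c1ccc(O)c2ncccc12)C1CCCC1` gives "not determined" (no result reported)
compound 2 `O=S(=O)(c1ccc(O)c2ncccc12)N1CCC(c2ccc(F)cc2)C1` gives 255 uL/min

In an ADME assay on cells (Hepatocyte, Rattus norvegicus) for pharmacokinetics (on this read-out higher numbers stand for fast clearance and lower numbers for slow clearance), compound 1 has no single number, so it stands nowhere on this scale; only compound 2 gives 255 uL/min. Compound 3 `O=S(=O)(c1cc(Cl)c(O)c2ncccc12)C1CCCC1` differs from compound 1 in one place: chloro in place of hydrogen on an aromatic carbon. With no step between measured compounds to lean on, the change cannot be sized or given a direction from the data; an effect beyond the scatter is possible but not shown. In this assay compound 3 is expected to give 150 uL/min, within a range from 50 uL/min to 450 uL/min.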

Compound 3, intrinsic clearance in a liver preparation (reported as CLH), per the amount of preparation that the assay uses: 18 uL/min
For compound 3 the middle estimate is 8.3-fold (0.92 log units) above the measured one, and the stated range ends above it.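

In this assay, among these compounds, compound 1 has no single number, so no step to compound 3 can be read. Whether chloro in place of hydrogen shifts clearance on this core stays open, and no supporting data bear on a cause.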